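Giving Up the 3,4-Dimethoxyphenyl on the Carbonyl Carbon

The compounds below may be only part of what the source reports. "The series", "measured", "known", "first", "only" and "open" are said of these compounds alone.

Among the compounds with values here, in a functional assay on MDA-MB-435 cells (Homo sapiens) for inhibition, read by sulforhodamine B assay, with a stated time of 48 h (a higher number here means that more compound is tolerated, a lower number that less compound is tolerated), compound 3 `COc1ccc(C(=O)/C=C/c2cc(-c3cc(OC)c(OC)c(OC)c3)n[nH]2)cc1OC` gives 5520 nM, the lower of the two actual numbers so far. The nearest is from compound 1 `COc1ccc(-c2cc(/C=C/C(=O)c3ccc(N)cc3)[nH]n2)cc1`, which gives a higher 38200 nM. For compound 2 `COc1cc(-c2cc(/C=C/C(=O)c3ccc(Cl)c(Cl)c3)[nH]n2)cc(OC)c1OC`, the reading is only a limit, > 100000 nM.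

Compound 4 `COc1cc(-c2cc(/C=C/C(=O)c3ccc(F)c(F)c3)[nH]n2)cc(OC)c1OC` carries 3,4-difluorophenyl in place of 3,4-dimethoxyphenyl on a carbonyl carbon. Within the data shown here, one measured step bears on this change: an at least 18-fold lower number from compound 2 to compound 3 (1.25 log units; beyond the scatter), where 3,4-dimethoxyphenyl replaced 3,4-dichlorophenyl at that same place. Compound 4 gives up the group whose arrival came with an at least 18-fold lower number from compound 2 to compound 3 (1.25 log units; beyond the scatter), so a step in the opposite direction, towards a higher number in this assay, is expected. Fluorine is not chlorine, however, and a single step is thin support, so the expected rise is more modest and uncertain. The expected change is a 5.4-fold higher number from compound 3 to compound 4 (0.74 log units; beyond the scatter). For compound 4 the estimate is 30000 nM, with an expected range from 7000 nM to 100000 nM.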

Compound 4, concentration lethal to 50% of the cells: > 100000 nM
Compound 4 ended at the assay's limit (the forecaster's own chance of this, stated with the estimate: 30%); at least 3.3-fold (0.52 log units) between middle value and limit.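

Replacing 3,4-dimethoxyphenyl with 3,4-difluorophenyl on the carbonyl carbon gave an at least 18-fold higher number from compound 3 to compound 4 (1.25 log units; beyond the scatter) in this assay. Until now this place rested on a single halogen-bearing group, whereas among compound 2, compound 3 and compound 4, which differ only here, the two halogen-bearing groups now both end at a limit and only 3,4-dimethoxyphenyl gives an actual number. The step between compound 2 and compound 4 cannot be read, so the two halogen-bearing groups cannot be ordered, as both readings are limits: the limit of > 100000 nM in this assay, at which 2 of the 4 values shown sit.

The compounds shown leave open whether the methoxy groups themselves matter at this place, a question that 3,4-dihydroxyphenyl or 3,4-dimethylphenyl on the carbonyl carbon would address. They also leave open whether any group here gives a lower number than compound 3, at 5520 nM.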